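Series notes: from compound 3 to compound 4

This account rests on a few compounds, and the source may have more. Where it says the series, first, only, none or still open, it means among the compounds named here.

Measured in an ADME assay on cells (Peritoneal macrophage cell, Mus musculus) for cytotoxicity, read by fluorescence and resazurin assay, with a stated time of 3 days; on this read-out lower numbers stand for higher toxicity in this test and higher numbers for lower toxicity in this test; each value is a limit:
- Compound 1 `O=C(NCc1ccccc1)Nc1[nH]nc(-c2ccccn2)c1Cl`: > 64000 nM
- Compound 2 `COc1ccc(C(=O)Nc2[nH]nc(-c3ccccn3)c2C2CC2)cc1`: > 64000 nM
- Compound 3 `COc1ccccc1C(=O)Nc1[nH]nc(-c2ccccn2)c1C1CC1`: > 51000 nM

Compound 3 gives only a limit and no number, at the limit of > 51000 nM in this assay, at which 1 of the 3 values shown sits. For the measured compounds named here, the other two compounds share (the limit of > 64000 nM in this assay, at which 2 of the 3 values shown sit), so no compound in the set has a measured half-maximal cytotoxic concentration.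

Compound 4 `O=C(NCc1ccccc1)Nc1[nH]nc(-c2ccccn2)c1C1CC1` is the next to be read, with benzylamino in place of 2-methoxyphenyl on a carbonyl carbon.

Going by the values given here, one measured step bears on this change, a step that the two limits leave unreadable from compound 2 to compound 3, and it gives no size to carry over. Compound 1 also holds benzylamino on a carbonyl carbon, and its result of > 64000 nM is a limit. With compound 1 and compound 3 both reported only as limits, nothing points to a rise in toxicity in this assay, and a further limit is the likeliest result.

No step beyond the usual scatter is expected, and the estimated step is a step that the limit leaves unreadable from compound 3 to compound 4.

The estimate for compound 4 is 60000 nM, with an expected range from 30000 nM to 100000 nM.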

Compound 4, half-maximal cytotoxic concentration: > 45000 nM
Compound 4 ended at the assay's limit; the forecaster's own chance of this, stated with the estimate: 85%; the middle value does not contradict the limit.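

In this assay compound 4 gives > 45000 nM, which is a limit and not a number. For the compounds shown here, compound 1, compound 2 and compound 3 are also reported only as limits, so no step to compound 4 can be read. The compounds shown leave open where the half-maximal cytotoxic concentration of any of them lies, and whether any of these changes shifts it.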